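This account rests on a few compounds, and the source may have more. Where it says the series, first, only, none or still open, it means among the compounds named here.

Working notes on the series

Compound 1 `COc1cc(/C=C2\C(=O)Nc3ccccc32)ccc1OCCCN1CCN(c2ncccc2C(F)(F)F)CC1` sits at the edge of a functional assay on A549 cells (Homo sapiens) for cytotoxicity, read by MTT assay, with a stated time of 48 h; on this read-out lower numbers stand for stronger inhibition and higher numbers for weaker inhibition: compound 1 gives > 20000 nM, which is a limit of the assay and not a number. Compound 2 `COc1cc(/C=C2\C(=O)Nc3ccc(Cl)cc32)ccc1OCCCN1CCN(c2ncccc2C(F)(F)F)CC1` gives 9530 nM in this assay. The step of an at least 2.0-fold lower number from compound 1 to compound 2 (0.32 log units; beyond the scatter) rests on that limit (the limit of > 20000 nM in this assay, at which 1 of the 2 values shown sits), so its true size is open. Within the data shown here, compound 2 therefore stands as the only compound with a number in this assay; the other value is a limit.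

Compound 3 `COc1cc(/C=C2\C(=O)Nc3ccc(C)cc32)ccc1OCCCN1CCN(c2ncccc2C(F)(F)F)CC1` carries methyl in place of chloro on an aromatic carbon. Among the measured compounds shown here, the only measured step that bears on this position is the one from compound 1 to compound 2, where chloro entered in place of hydrogen; no step swaps chloro for methyl. Expected for compound 3 is a step of a 1.3-fold higher number from compound 2 to compound 3 (0.10 log units; within the scatter) that stays within the scatter, leaning slightly towards a higher number. The estimate for compound 3 in this assay is 12000 nM, within 5000 nM to 30000 nM.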

Compound 3, half-maximal inhibitory concentration: > 20000 nM
Compound 3: no number, only a limit (the forecaster's own chance of this, stated with the estimate: 25%); middle value at least 1.6-fold (0.22 log units) away from the limit.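

The swap of chloro for methyl, one heavy atom for another on the same aromatic carbon, gives an at least 2.0-fold higher number from compound 2 to compound 3 (0.32 log units; beyond the scatter) in this assay, so at this position the lower number does not carry over from chloro to methyl. Compound 3 gives > 20000 nM, which is a limit of the assay and not a number. Only the chloro compound therefore has a number so far, and the step from hydrogen to methyl cannot be read: the limit of > 20000 nM in this assay, at which 2 of the 3 values shown sit.

As far as these compounds go, the true size of the step from chloro to methyl remains open, as does whether the lower number belongs to chloro alone. Fluoro, bromo, methoxy or a nitrile on this carbon would show whether other groups at this position give a number in this assay.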